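The source may report more compounds than this note shows. Statements on the series, on what has been measured and on what is new or still open speak of the compounds shown alone.

Measured compounds in a functional assay on HCT-116 cells (Homo sapiens) for antiproliferative activity, read by sulforhodamine B assay, with a stated time of 72 h; on this read-out higher numbers stand for weaker inhibition and lower numbers for stronger inhibition:

compound 1 `Cn1ncc(Cl)c1-c1cc(C(=O)N[C@@H]2CN[C@H](CC(O)CO)C[C@H]2c2ccc(F)c(F)c2)oc1Cl` gives 800 nM
compound 2 `Cn1ncc(Cl)c1-c1cc(C(=O)N[C@@H]2CN[C@H](CC(O)CO)C[C@H]2c2ccc(Cl)c(Cl)c2)oc1Cl` gives 1110 nM
compound 3 `C=CC[C@@H]1C[C@@H](c2ccc(Cl)c(Cl)c2)[C@H](NC(=O)c2cc(-c3c(Cl)cnn3C)c(Cl)o2)CN1` gives 780 nM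

Compound 2 returns the largest number of the three, yet the steps of a 1.4-fold higher number from compound 1 to compound 2 (0.14 log units; within the scatter) and a 1.4-fold lower number from compound 2 to compound 3 (0.15 log units; within the scatter) both lie within the scatter, so the three compounds are not separated by these data.

Compound 4 `Cn1ncc(Cl)c1-c1cc(C(=O)N[C@@H]2CN[C@H](CC(=O)NCCO)C[C@H]2c2ccc(Cl)c(Cl)c2)oc1Cl` differs from compound 2 at the side chain: (2-hydroxyethyl)carbamoyl in place of 1,2-dihydroxyethyl on a saturated chain carbon bound to a saturated ring carbon. Within the data shown here, the one measured step at this place, a 1.4-fold lower number from compound 2 to compound 3 (0.15 log units; within the scatter), exchanged the 1,2-dihydroxyethyl for vinyl and produced no movement beyond the scatter. The aryl step a 1.4-fold higher number from compound 1 to compound 2 (0.14 log units; within the scatter) does not touch this position and was likewise flat. With only a flat step at the same place to draw on, the expectation for compound 4 in this assay is no step beyond the scatter, in either direction, giving a 1.1-fold lower number from compound 2 to compound 4 (0.05 log units; within the scatter).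

Compound 4 is therefore estimated at 1000 nM, with a range of 450 nM to 2500 nM in this assay.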

Compound 4, half-maximal inhibitory concentration: 670 nM
Compound 4: the middle estimate sits 1.5-fold (0.17 log units) above what was measured; the range from low to high includes it.
By their numbers in this assay, from the lowest: compounds 4, 3, 1 and 2 (each within the scatter of the next).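

In this assay, (2-hydroxyethyl)carbamoyl on a saturated chain carbon bound to a saturated ring carbon gives a 1.7-fold lower number from compound 2 to compound 4 (0.22 log units; within the scatter) against 1,2-dihydroxyethyl and a 1.2-fold lower number from compound 3 to compound 4 (0.07 log units; within the scatter) against vinyl, so neither change separates the compounds. With compounds 2, 3 and 4, the flat result at this place now extends to a group of 6 heavy atoms that brings a double bond outside aromatic rings, with hydrogen-bond donor and acceptor counts unchanged from 1,2-dihydroxyethyl. No supporting data bear on why these changes leave the read-out within the scatter.

On these data alone, whether an amine, a carboxylic acid or a longer chain at this place would give a step beyond the scatter remains open. Also open, as far as these compounds go, is whether (2-hydroxyethyl)carbamoyl behaves the same way alongside 3,4-difluorophenyl.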